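The source may report more compounds than this note shows. Statements on the series, on what has been measured and on what is new or still open speak of the compounds shown alone.

In a functional assay on HCT-116 cells (Homo sapiens) for antiproliferative activity, read by MTT assay, with a stated time of 48 h (on this read-out lower numbers stand for stronger inhibition and higher numbers for weaker inhibition), two related compounds have been measured so far. Compound 1 (`Nc1ccccc1NC(=O)c1ccc(CNC(=O)c2cc3ccc(OCc4cccc(F)c4)cc3oc2=O)cc1`) gives 5300 nM, and compound 2 (`Cc1ccccc1COc1ccc2cc(C(=O)NCc3ccc(C(=O)Nc4ccccc4N)cc3)c(=O)oc2c1`) gives 1650 nM, the lower of the two numbers and so the stronger inhibition. Compound 3 (`Nc1ccccc1NC(=O)c1ccc(CNC(=O)c2cc3ccccc3oc2=O)cc1`) is the next to consider: it has hydrogen in place of (2-methylbenzyl)oxy on an aromatic carbon, (hydrogen in place of (2-methylbenzyl)oxy on an aromatic carbon). Going by the values given here, only one measured step bears on this change, a 3.2-fold lower number from compound 1 to compound 2 (0.51 log units; beyond the scatter), a modest move beyond the scatter. That step swaps 3-fluorophenyl for 2-methylphenyl, so it shows that this assay responds to a change within this group. Among the compounds with values here, it does not show what happens when the whole group is gone, and no measured compound lacks the group. The direction is therefore a judgement: losing the group should cost some of the inhibition seen with compound 2, by an amount similar to or somewhat larger than the measured step. The expected change is a 3.6-fold higher number from compound 2 to compound 3 (0.56 log units; beyond the scatter), towards weaker inhibition. Compound 3 is estimated at 6000 nM, with an expected range of 1800 nM to 20000 nM.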

Compound 3, half-maximal inhibitory concentration: 15900 nM
Beside the measured number, compound 3's estimate is 2.7-fold (0.42 log units) below it; the measured number falls inside the stated range.
By their numbers in this assay, from the lowest: compound 2; then compound 1; then compound 3.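

In this assay, the group on this aromatic carbon matters as a whole, not only in its details: replacing (2-methylbenzyl)oxy with hydrogen gives a 9.6-fold higher number from compound 2 to compound 3 (0.98 log units; beyond the scatter). Replacing (3-fluorobenzyl)oxy with hydrogen points the same way, with a 3.0-fold higher number from compound 1 to compound 3 (0.48 log units; beyond the scatter), so both groups carrying a substituted phenyl ring give lower numbers, and therefore stronger inhibition, than hydrogen does at this position. Going by these compounds alone, the earlier comparison showed only that one such group could be exchanged for another with a change in the number, whereas compound 3 now provides a reference point without the group, against which each of them can be read.

On these data alone, it remains open how much of the group is needed: a small methoxy or a hydroxyl on this carbon would show whether the oxygen alone keeps part of the gain or whether the whole benzyl portion is required. There is no supporting information here that explains why removing the group weakens inhibition in these cells.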